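The source may report more compounds than this note shows. Statements on the series, on what has been measured and on what is new or still open speak of the compounds shown alone.

Measured compounds:
compound 1 `C=CC(=O)Nc1cc(Nc2nc(C)cc(-c3cn(C)c4ccccc34)n2)c(OC)cc1N(C)CCN(C)C`, 4810 nM
compound 2 `CC/C=C\C(=O)Nc1cc(Nc2nc(C)cc(-c3cn(C)c4ccccc34)n2)c(OC)cc1N(C)CCN(C)C`, 1990 nM
compound 3 `C=CC(=O)Nc1cc(Nc2ncc(C#N)c(-c3cn(C)c4ccc(F)cc34)n2)c(OC)cc1N(C)CCN(C)C`, 11400 nM

All values are from a functional assay on NCI-H1975 cells (Homo sapiens) for antiproliferative activity, read by MTT assay, with a stated time of 72 h; on this read-out higher numbers stand for weaker inhibition and lower numbers for stronger inhibition. Compound 3 gives the highest number of the three; the difference between its core and the core of compound 1 is not broken down here. Within the core of compound 1, the change but-1-en-1-yl in place of vinyl on a carbonyl carbon gave a 2.4-fold lower number from compound 1 to compound 2 (0.38 log units; beyond the scatter).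

Compound 4 `CC/C=C\C(=O)Nc1cc(Nc2ncc(C#N)c(-c3cn(C)c4ccc(F)cc34)n2)c(OC)cc1N(C)CCN(C)C` is not yet measured. It carries the same change on the core of compound 3, (but-1-en-1-yl in place of vinyl on a carbonyl carbon), at the same place. Because compound 1 to compound 2 showed a 2.4-fold lower number from compound 1 to compound 2 (0.38 log units; beyond the scatter), a step of similar size is expected here, a 2.3-fold lower number from compound 3 to compound 4 (0.36 log units; beyond the scatter), though this rests on a single earlier pair. For compound 4 the expected value in this assay is 5000 nM, with a range from 2200 nM to 12000 nM.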

Compound 4, half-maximal inhibitory concentration: 10200 nM
Estimate against measurement, compound 4: 2.0-fold (0.31 log units) below; the range from low to high includes it.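

On the core of compound 3, but-1-en-1-yl in place of vinyl on a carbonyl carbon gives, in this assay, a 1.1-fold lower number from compound 3 to compound 4 (0.05 log units; within the scatter), so here the change leaves the number within the scatter. Set beside the step on the core of compound 1, the two steps do not differ beyond what two such steps allow: the same change on two cores in this assay, a 2.4-fold lower number (0.38 log units; beyond the scatter) from compound 1 to compound 2 and a 1.1-fold lower number (0.05 log units; within the scatter) from compound 3 to compound 4, 2.2-fold (0.33 log units) apart, within the scatter of two such steps. This fits a change that carries over from one core to the other, but two pairs, one of them within the scatter, establish neither a shared step size nor a dependence on the core.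

Still open, on these data alone, is whether a longer chain in place of but-1-en-1-yl, or one ending in a dimethylamino group, would move the number on either core. As far as these compounds go, whether the step holds on a third core also remains open.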